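The compounds below may be only part of what the source reports. "The series", "measured", "known", "first", "only" and "open" are said of these compounds alone.

Notes on the series. The shared core of compound 1, `COc1cccc(/C=C2\CCC/C(=C\c3cccc(Cl)c3)C2=O)c1OC`, carries 3-chlorophenyl on a double-bonded chain carbon bound to a double-bonded ring carbon. In a functional assay on A549 cells (Homo sapiens) for cytotoxicity, read by MTT assay, with a stated time of 72 h (a higher number here means a weaker inhibitor, a lower number a stronger inhibitor), compound 1 gives only a limit, > 20000 nM. Compound 2, `COc1ccc(/C=C2\CCC/C(=C\c3cccc(OC)c3OC)C2=O)cc1`, carries 4-methoxyphenyl on the same double-bonded chain carbon. In this assay compound 2 likewise gives only a limit, > 20000 nM. The step that the two limits leave unreadable from compound 1 to compound 2 cannot be read because of the limit of > 20000 nM in this assay, at which 2 of the 2 values shown sit. Compound 2 therefore stands at the limit of this assay, with no number to place it against compound 1.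

For the measured compounds named here, compound 3, `COc1cccc(/C=C2\CCC/C(=C\c3cc(Cl)cc(Cl)c3)C2=O)c1OC`, is to be measured in this assay. 3,5-dichlorophenyl in place of 4-methoxyphenyl on a double-bonded chain carbon bound to a double-bonded ring carbon The only measured step that bears on this double-bonded chain carbon is the one from compound 1 to compound 2, and its size is not readable, so it gives no direction. The expected step is a step that the limit leaves unreadable from compound 2 to compound 3, nothing beyond the scatter, with compound 3 most likely again reported only as a limit. Compound 3 is estimated at 30000 nM, with a range from 8000 nM to 100000 nM.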

Compound 3, half-maximal inhibitory concentration: 12500 nM
Estimate against measurement, compound 3: 2.4-fold (0.38 log units) above, within the range that was stated.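

For the compounds shown here, compound 3 is the first compound here to give a number rather than a limit in this assay, so a readable value now exists on the double-bonded chain carbon bound to a double-bonded ring carbon, and it belongs to 3,5-dichlorophenyl. The comparison with 4-methoxyphenyl gives only a floor, an at least 1.6-fold lower number from compound 2 to compound 3 (0.20 log units; that floor lies within the scatter), and the comparison with 3-chlorophenyl, chloro in place of hydrogen on an aromatic carbon, gives another, an at least 1.6-fold lower number from compound 1 to compound 3 (0.20 log units; that floor lies within the scatter), so neither change is shown to exceed the scatter. On these data alone, the true size of both steps stays unknown because compound 3 is set against two compounds that carry no number, and the step between those two also cannot be read: the limit of > 20000 nM in this assay, at which 2 of the 3 values shown sit.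

The compounds shown leave open whether the second chloro matters at all, and whether any group on this carbon can bring the value far from the limit of the assay. Also open, as far as these compounds go, is how an amine or a carboxylic acid on this aromatic ring would read in this assay, and whether the dimethoxyphenyl side of the shared core contributes to the value of compound 3.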